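The compounds below may be only part of what the source reports. "The series", "measured", "known", "first", "only" and "open" are said of these compounds alone.

Measured compounds:

- Compound 1, `CCn1cc(-c2ccnc(Nc3ccc(OC)cc3OC)n2)c2ccccc21`, gives 3590 nM in a functional assay on MV4-11 cells (Homo sapiens) for inhibition, read by resazurin assay, with a stated time of 72 h; on this read-out higher numbers stand for weaker inhibition of growth and lower numbers for stronger inhibition of growth.
- Compound 2, `COCCSc1nc(C)c(-c2ccnc(Nc3ccc(OC)cc3OC)n2)s1`, gives 810 nM in this assay.
- Compound 3, `COc1ccc(Nc2nccc(-c3cn(C4CCCC4)c4ccccc34)n2)c(OC)c1`, gives 1740 nM in this assay.

Compound 2 has the lowest number of the three, and so the strongest inhibition of growth seen here; its gaps to compound 3 and to compound 1 both lie beyond the scatter, with compound 3 nearer and compound 1 further away.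

Compound 4, `CCSc1nc(C)c(-c2ccnc(Nc3ccc(OC)cc3OC)n2)s1`, differs from compound 2 in one place: hydrogen in place of methoxy on a saturated chain carbon, two bonds along the chain from a sulfur. Going by the values given here, the only measured step, a 2.1-fold lower number from compound 1 to compound 3 (0.31 log units; beyond the scatter), concerns a different change on the core shared by compound 1 and compound 3, not the sulfur-linked chain of compound 2, so it gives no direct guidance here. With nothing comparable measured, there is no ground to expect a step beyond the scatter in this assay in either direction. Compound 4 is therefore estimated at 900 nM, with an expected range from 400 nM to 2000 nM. That estimate corresponds to an expected step of a 1.1-fold higher number from compound 2 to compound 4 (0.05 log units; within the scatter).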

Compound 4, concentration for 50% growth inhibition: 32400 nM
Compound 4: the middle estimate sits 36-fold (1.56 log units) below what was measured; measured number above the stated range.
By their numbers in this assay, from the lowest: compound 2; then compound 3; then compound 1; then compound 4.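

The sulfur-linked chain of compound 2 proves to be far from a neutral part of the molecule: in this assay, putting hydrogen in place of methoxy gives a 40-fold higher number from compound 2 to compound 4 (1.60 log units; beyond the scatter), which means much weaker inhibition of growth from the loss of only 2 heavy atoms. Going by these compounds alone, this step is also much larger than the only other step available, a 2.1-fold lower number from compound 1 to compound 3 (0.31 log units; beyond the scatter), which involves a change at a different place on a different core. No measurement available here explains why the methoxy matters so much.

This single pair cannot separate the part played by the oxygen from that of the methyl carbon at the chain end. It also leaves open how a hydroxyl, an amine or a longer ether chain at the same place would compare with methoxy.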